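Compound 2 and a Single Ring Swap to Compound 3

A few compounds are considered here, and "the series" means these few. Any claim that something is new, unique, unknown or untested is made for them only; others in the source may bear on it.

Compound 2 `N#Cc1c(Nc2ccccc2Cl)nc(SCc2cn(Cc3ccccc3Cl)nn2)nc1-c1ccccc1` was tested in a functional assay on ECa-109 cells (Homo sapiens) for inhibition, read by MTT assay, with a stated time of 72 h (on this read-out lower numbers stand for stronger inhibition and higher numbers for weaker inhibition), and gave 28500 nM. Compound 1 `C#CCSc1nc(Nc2cccc(Cl)c2)c(C#N)c(-c2ccccc2)n1` reached only a limit in this assay, > 128000 nM. Compound 2 thus holds the only measured number shown. The other entry is the limit of > 128000 nM in this assay, at which 1 of the 2 values shown sits. Compound 3 `N#Cc1c(Nc2ccc(F)cc2)nc(SCc2cn(Cc3ccccc3Cl)nn2)nc1-c1ccccc1` differs from compound 2 by one change: 4-fluorophenyl in place of 2-chlorophenyl on a nitrogen on an aromatic ring. Going by the values given here, no measured pair shows the size of such a step, so no shift beyond the usual scatter is assumed, and the step expected is a 1.1-fold lower number from compound 2 to compound 3 (0.06 log units; within the scatter). Compound 3 is estimated at 25000 nM, with a range from 8000 nM to 80000 nM.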

Compound 3, half-maximal inhibitory concentration: 25800 nM
Compound 3: middle estimate off by 1.0-fold (0.01 log units), on the low side, and the stated range covers the measured number.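

In this assay, going by these compounds alone, this swap on a nitrogen on an aromatic ring gives a 1.1-fold lower number from compound 2 to compound 3 (0.04 log units; within the scatter) and is the first measured step at this place. In this single pair, 4-fluorophenyl and 2-chlorophenyl cannot be told apart. Nothing in the data shown accounts for this result.

From the compounds shown here alone, it remains open whether a different group on this nitrogen, such as a pyridine ring or a cyclohexyl ring, would shift the number beyond the scatter. The same question stands for an amine or a carboxylic acid on the phenyl ring.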